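The source may hold more compounds than are shown below. What is called first, only, known or untested is meant among the compounds shown, and "the series" means these compounds.

For the measured compounds named here, compound 2 `Fc1cccc(Nc2nc(-c3cccc(F)c3)nc3ccc(F)cc23)c1` gives 48700 nM in a functional assay on MCF7 cells (Homo sapiens) for cytotoxicity, read by MTT assay, with a stated time of 48 h (a lower number here means a stronger inhibitor, a higher number a weaker inhibitor), the higher of the two numbers measured so far, though its nearest neighbour, compound 1 `COc1ccc(Nc2nc(-c3cccc(F)c3)nc3ccc(F)cc23)cc1`, gives 48400 nM, and the step of a 1.0-fold higher number from compound 1 to compound 2 (0.00 log units; within the scatter) lies within the scatter, so the two cannot be told apart. Compound 3 `Fc1cccc(-c2nc(Nc3ccccc3Br)c3cc(F)ccc3n2)c1` has not yet been measured. It differs from compound 2 by 2-bromophenyl in place of 3-fluorophenyl on a nitrogen on an aromatic ring. Going by the values given here, the only measured step that bears on this change is the one from compound 1 to compound 2, which also exchanged one aryl group on that nitrogen for another and moved the number not at all. On that basis the expected step of a 1.0-fold higher number from compound 2 to compound 3 (0.01 log units; within the scatter) is small, with no direction beyond the scatter. Compound 3 is therefore estimated to give 50000 nM in this assay, within a range of 20000 nM to 130000 nM.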

Compound 3, half-maximal inhibitory concentration: > 50000 nM
Compound 3 ended at the assay's limit; the forecaster's own chance of this, stated with the estimate: 20%; the middle value lies on the limit itself.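

The reading for compound 3 in this assay is a limit and not a number: the limit of > 50000 nM in this assay, at which 1 of the 3 values shown sits. Read as floors, the steps are an at least 1.0-fold higher number from compound 2 to compound 3 (0.01 log units; that floor lies within the scatter) and an at least 1.0-fold higher number from compound 1 to compound 3 (0.01 log units; that floor lies within the scatter), so neither shows a real difference, and how far the true number lies past the limit stays unknown. What the result adds is that a third aryl group on this nitrogen, now 2-bromophenyl, gives no sign of a lower number than 3-fluorophenyl or 4-methoxyphenyl did. The compounds shown leave open whether any group on this nitrogen can bring the number down, since all three shown are substituted phenyl rings. A group of another kind there, such as a longer chain ending in an amine or a phenyl ring carrying a carboxylic acid, remains untested in what is shown here.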